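Replacing 3-hydroxypropyl with 1-methylpiperidin-4-yl on a shared core

The source may hold more compounds than are shown below. What is called first, only, known or untested is meant among the compounds shown, and "the series" means these compounds.

In a physicochemical assay for solubility, with a stated time of 3 days, at pH 2 (a higher number here means a more soluble compound, a lower number a less soluble compound), compound 1 `NC(=O)c1ccc2[nH]c(-c3ccc(OCCCO)cc3)nc2c1` gives 185000 nM. Among the measured compounds shown here, that is the only number available, so compound 1 cannot yet be ranked against anything. For compound 2 `CN1CCC(Oc2ccc(-c3nc4cc(C(N)=O)ccc4[nH]3)cc2)C1` the entry reads "not determined" (no result reported), which leaves the series without a second value for comparison.

The next compound to be tested is compound 3 `CN1CCC(Oc2ccc(-c3nc4cc(C(N)=O)ccc4[nH]3)cc2)CC1`. It keeps the core of compound 1 and changes one group, on an oxygen on an aromatic ring: 1-methylpiperidin-4-yl in place of 3-hydroxypropyl on an oxygen on an aromatic ring. In words, 1-methylpiperidin-4-yl stands in place of 3-hydroxypropyl, so a group with no ring gives way to one with a six-membered non-aromatic ring holding one hetero atom.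

For the measured compounds named here, no measured step between two compounds is available to calibrate this change, so any forecast rests on the structural difference and on the single value of compound 1. The expected change is upward and beyond the usual scatter, with an estimated size of a 3.8-fold higher number from compound 1 to compound 3 (0.58 log units; beyond the scatter). Compound 3 is estimated to give 700000 nM in this assay, with an expected range of 200000 nM to 2000000 nM.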

Compound 3, solubility: > 400000 nM
Compound 3 ended at the assay's limit; the forecaster's own chance of this, stated with the estimate: 25%; the middle value lies beyond the limit too.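

In this assay, compound 3 reads > 400000 nM, which is a limit of the assay and not a number. Among the compounds shown here, until now, the oxygen on an aromatic ring had offered only a single value and no step, whereas 1-methylpiperidin-4-yl in place of 3-hydroxypropyl at this place now gives an at least 2.1-fold higher number from compound 1 to compound 3 (0.33 log units; beyond the scatter), the first readable change and one that points upward past the usual scatter. As far as these compounds go, that step is a lower bound on the change and not its size, so how far compound 3 truly lies from compound 1 stays unknown, and the limit is one that the scale of this read-out sets: the limit of > 400000 nM in this assay, at which 1 of the 3 values shown sits.

The compounds shown leave open whether the rise goes with the six-membered ring or with its nitrogen, since both enter together in this single change, and an open-chain amine such as 3-(dimethylamino)propyl on the same oxygen, or a tetrahydropyran-4-yl ring carrying oxygen in place of that nitrogen, would separate the two. They also leave open how any such group would read at pH values other than the one stated for this assay.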